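The source may report more compounds than this note shows. Statements on the series, on what has been measured and on what is new or still open speak of the compounds shown alone.

Measured so far:
- compound 1 `CCOC(=O)c1c(C)nc(-c2ccc(C#N)cc2)n1OC`: 13400 nM
- compound 2 `CCOC(=O)c1c(C)nc(-c2cccc(C#N)c2)n1C`: 22100 nM

In a functional assay on a cell-free system (plasma, Oryctolagus cuniculus) for inhibition, with stated times of 5 min, 1 min and 6 min (on this read-out higher numbers stand for weaker inhibition and lower numbers for stronger inhibition), compound 2 gives 22100 nM, which lies within the usual scatter of compound 1 at 13400 nM. Within the data shown here, the two values therefore set no order between these compounds.

The next compound is compound 3 `CCOCCOn1c(-c2cccc(C#N)c2)nc(C)c1C(=O)OCC`, in which 2-ethoxyethoxy takes the place of methyl on an aromatic nitrogen (2-ethoxyethoxy in place of methyl on an aromatic nitrogen). Among the measured compounds shown here, no measured step between compounds differing in one place bears on this change, so the expectation rests only on the two values in hand. In this assay, no step beyond the scatter is expected, and neither direction is favoured. The expected change is a 1.4-fold lower number from compound 2 to compound 3 (0.14 log units; within the scatter). Compound 3 is estimated at 16000 nM, with an expected range of 5000 nM to 45000 nM.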

Compound 3, half-maximal inhibitory concentration: 6250 nM
For compound 3 the middle estimate is 2.6-fold (0.41 log units) above the measured one; the measured number falls inside the stated range.
By their numbers in this assay, from the lowest: compound 3; then compounds 1 and 2 (each within the scatter of the next).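

In this assay, among these compounds, the aromatic nitrogen proves to be a place where the substituent can move the read-out: 2-ethoxyethoxy in place of methyl gives a 3.5-fold lower number from compound 2 to compound 3 (0.55 log units; beyond the scatter) and is the first step to lie beyond the scatter. The position therefore accepts a chain well beyond methyl without loss of inhibition, and on this single pair inhibition is stronger with the chain. No measured data on the compounds explain this step.

The compounds shown leave open whether the step follows the length of the chain or its oxygen atoms. An all-carbon chain on this nitrogen, or a chain ending in an amine or a carboxylic acid, would separate these readings and show how far the trend extends.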